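Working notes: fluoro to trifluoromethyl swap, compound 4

A few compounds are considered here, and "the series" means these few. Any claim that something is new, unique, unknown or untested is made for them only; others in the source may bear on it.

Measured compounds:
compound 1 `CNc1nc(C)c(C(=O)N/N=C/c2cc(C(F)(F)F)cc(C(F)(F)F)c2)s1` — > 100 ug/mL
compound 2 `Cc1nc(N(C)C(=O)NC(=O)c2c(F)cccc2F)sc1C(=O)N/N=C/c1ccc(F)cc1` — > 100 ug/mL
compound 3 `CNc1nc(C(F)(F)F)c(C(=O)N/N=C/c2ccccc2C(F)(F)F)s1` — > 100 ug/mL

In a functional assay on HepG2 cells (Homo sapiens) for inhibition, read by MTT assay, with a stated time of 72 h (a lower number here means a stronger inhibitor, a higher number a weaker inhibitor), compound 1 reaches only the limit of the assay, > 100 ug/mL. In this assay compound 2 likewise gives only the limit, > 100 ug/mL. Compound 3 too gives only the limit, > 100 ug/mL. Among the compounds with values here, compound 2 thus sits at the limit of > 100 ug/mL in this assay, at which 3 of the 3 values shown sit, and cannot be ranked against compound 1 or compound 3; no measured step between any two compounds exists. Compound 4 `Cc1nc(N(C)C(=O)NC(=O)c2c(F)cccc2F)sc1C(=O)N/N=C/c1ccc(C(F)(F)F)cc1` differs from compound 2 by trifluoromethyl in place of fluoro on an aromatic carbon. From the compounds shown here alone, with every measured value a limit, the size of this change in this assay is unknown. Compound 4 is expected to stay at the limit, so the step that the limit leaves unreadable from compound 2 to compound 4 is estimated as none beyond the scatter. Compound 4 is estimated at 150 ug/mL, range 50 ug/mL to 400 ug/mL.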

Compound 4, half-maximal inhibitory concentration: > 100 ug/mL
Compound 4 gave a limit, no number; the forecaster's own chance of this, stated with the estimate: 85%; the middle value is on the limit's open side.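

No step can be read from compound 2 to compound 4, because both values are limits: the limit of > 100 ug/mL in this assay, at which 4 of the 4 values shown sit.

The compounds shown leave open whether swapping fluoro for trifluoromethyl has any effect in this assay, and what structure would give a measurable value there.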